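Nitro to methyl on the benzyl ether: expectation for compound 3

The source may hold more compounds than are shown below. What is called first, only, known or untested is meant among the compounds shown, and "the series" means these compounds.

Within the data shown here, compound 2 `O=c1c(OCc2ccc([N+](=O)[O-])cc2)c(-c2ccccc2)oc2cc(O)cc(O)c12` gives 40000 nM in an ADME assay on Huh-5-2 cells (Homo sapiens) for cytotoxicity, read by WST assay, with a stated time of 3 days (on this read-out higher numbers stand for lower toxicity in this test and lower numbers for higher toxicity in this test), and holds the highest of the two numbers so far; the nearest, compound 1 `O=c1c(OCc2cccc([N+](=O)[O-])c2)c(-c2ccccc2)oc2cc(O)cc(O)c12`, gives 31000 nM, and the step of a 1.3-fold higher number from compound 1 to compound 2 (0.11 log units; within the scatter) stays within the scatter. Compound 3 `Cc1ccc(COc2c(-c3ccccc3)oc3cc(O)cc(O)c3c2=O)cc1` differs from compound 2 by methyl in place of nitro on an aromatic carbon. Among the measured compounds shown here, the single measured step only moved the nitro group between aromatic carbons and did not reach beyond the scatter; no measured step exchanges the nitro group itself, so nothing in these numbers points to a direction. For compound 3 a step of no change at the digits printed from compound 2 to compound 3 (within the scatter) in this assay is expected, nothing beyond the scatter. Compound 3 is estimated at 40000 nM in this assay, with a range from 15000 nM to 100000 nM.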

Compound 3, half-maximal cytotoxic concentration: 40000 nM
Estimate against measurement, compound 3: no gap at the digits printed, and the stated range covers the measured number.
By their numbers in this assay, from the lowest: compounds 1, 2 and 3 (each within the scatter of the next).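

In this assay the exchange of nitro for methyl on the aromatic carbon, para to a large group, gives no change at the digits printed from compound 2 to compound 3 (within the scatter) and the change from 3-nitrophenyl to 4-methylphenyl gives a 1.3-fold higher number from compound 1 to compound 3 (0.11 log units; within the scatter). Both steps stay within the scatter, so this position now tolerates the loss of both nitro oxygens and the nitrogen with no readable shift in this read-out. Nothing available bears on why the number holds. Still open, from the compounds shown here alone, is whether an amine or a carboxylic acid at this aromatic carbon would leave the number in place. Going by these compounds, a longer chain there is equally open.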